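A few compounds are considered here, and "the series" means these few. Any claim that something is new, unique, unknown or untested is made for them only; others in the source may bear on it.

Working notes on the series. The chain-shortened analogue compound 1 `c1cnc(CN(CCCN2CCNCC2)[C@H]2CCCc3cccnc32)nc1` and compound 2 `c1ccc2c(c1)CN[C@@H](CN(CCCCN1CCNCC1)[C@H]1CCCc3cccnc31)C2` have both been run in an ADME assay on microsomes from liver (Homo sapiens) for metabolic stability, read by LC-MS, with a stated time of 10 min, tested at 0.5 uM; on this read-out higher numbers stand for a more stable compound and lower numbers for a less stable compound. In this assay compound 1 gives 100%. Compound 2 gives 82%, the lowest of the two numbers; the nearest figure belongs to compound 1, which sits higher by a margin beyond the usual scatter. No single-point comparison between the two is drawn here, since they differ in more than one place.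

The next compound, compound 3 `c1ccc2c(c1)CN[C@@H](CN(CCCN1CCN(C3CC3)CC1)[C@H]1CCCc3cccnc31)C2`, has not been tested. Its difference from compound 2 is 4-cyclopropylpiperazin-1-yl in place of (piperazin-1-yl)methyl on a saturated chain carbon, three bonds along the chain from an amine nitrogen. The ring count stays at one six-membered ring on the chain, a three-membered ring is added, and the hydrogen-bond donor on that ring is lost.

From compound 2 as the only direct reference, a modest downward step of a number 12 percentage points lower from compound 2 to compound 3 (beyond the scatter) is expected, close to the edge of the scatter. Compound 3 is therefore estimated at 70% in this assay, with a range from 45% to 95%.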

Compound 3, percent of the compound remaining: 21%
Estimate against measurement, compound 3: 49 percentage points above; measured number outside the range, below it.
By their numbers in this assay, from the lowest: compound 3; then compound 2; then compound 1.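

In this assay, 4-cyclopropylpiperazin-1-yl in place of (piperazin-1-yl)methyl on a saturated chain carbon, three bonds along the chain from an amine nitrogen, gives a number 61 percentage points lower from compound 2 to compound 3 (beyond the scatter), a large step. This place on the chain is therefore sensitive on this read-out: a single change, which adds a three-membered ring and removes the hydrogen-bond donor on the six-membered ring, moves the number well beyond the scatter. No measurement at hand bears on what lies behind the step.

The same difference also reads 2-(piperazin-1-yl)ethyl to (4-cyclopropylpiperazin-1-yl)methyl, and the shares of the cyclopropyl group and of the chain remain unseparated. Open too, as far as these compounds go, is where a 4-methylpiperazin-1-yl or 4-acetylpiperazin-1-yl group in this place would fall on this read-out.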